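The source may hold more compounds than are shown below. What is called first, only, known or untested is meant among the compounds shown, and "the series" means these compounds.

Compound 1 `CNC(=O)c1cc(C(=O)NC2CCOCC2)n([C@@H](C)c2ccccc2)n1`: 3.6
Compound 2 `CNC(=O)c1cc(C(=O)N[C@H]2[C@@H]3C[C@@H](O)C[C@@H]32)n([C@@H](C)c2cccc(Cl)c2)n1`: 3.4
Compound 3 `CNC(=O)c1cc(C(=O)N[C@H]2CC[C@H](O)CC2)c([C@@H](C)c2cccc(F)c2)o1`: 4.1

These three compounds have each been measured in a physicochemical assay for lipophilicity; a lower number here means a more polar compound, a higher number a more lipophilic compound. Among the three numbers, compound 1 stands second highest. Its nearest neighbour is compound 2, whose value lies lower by an amount within the usual scatter of this assay, so the two cannot be ordered. Compound 3 lies furthest from compound 1, with a value higher by an amount beyond the scatter.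

Compound 4 `CNC(=O)c1cc(C(=O)NCCO)n([C@@H](C)c2ccccc2)n1` has not yet been measured. It differs from compound 1 in one place: 2-hydroxyethyl in place of oxan-4-yl on an amide-type nitrogen. Going by the values given here, no measured pair in this set shows the effect of this kind of exchange, so the expectation rests on the structural change alone: a smaller group without a ring, carrying one hydrogen-bond donor where compound 1 carries none at that position. On that basis, a fall in this assay beyond the scatter is expected; the change is estimated to amount to a number 0.80 log units lower from compound 1 to compound 4 (beyond the scatter). Compound 4 is therefore expected to come in near 2.8, with the estimate ranging from 2.3 to 3.3.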

Compound 4, distribution coefficient: 2.4
Beside the measured number, compound 4's estimate is 0.40 log units above it, within the range that was stated.
By their numbers in this assay, from the lowest: compound 4; then compounds 2 and 1 (each within the scatter of the next); then compound 3.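

Going by these compounds alone, with the rest of compound 1 held fixed, replacing oxan-4-yl with 2-hydroxyethyl on the amide-type nitrogen gives the first direct reading of this position in this assay, and the exchange comes out as a number 1.20 log units lower from compound 1 to compound 4 (beyond the scatter). The earlier compounds shown here differ from one another in more than one place, so they could not show that this single position can by itself move the number by so much. Several things change at once, however: the ring leaves, the group becomes smaller and a hydrogen-bond donor enters, and no independent evidence says which of these matters for the size of the step.

The compounds shown leave open how much of the step would remain with a 2-methoxyethyl group, which has an open chain but no hydroxyl, or with a longer 3-hydroxypropyl chain on the same nitrogen. They also leave open how a 2-aminoethyl group or a carboxymethyl group, which brings in a carboxylic acid, would read at this place in this assay.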